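A Bromine Replaces the Side Group of Compound 2

This account rests on a few compounds, and the source may have more. Where it says the series, first, only, none or still open, it means among the compounds named here.

In a functional assay on U-251 cells (Homo sapiens) for cytotoxicity (on this read-out higher numbers stand for weaker inhibition of growth and lower numbers for stronger inhibition of growth), compound 1 (`COc1ccc(C2=C(c3ccc(SC)cc3)CC3CCCN3C2=O)cc1O`) gives 5000 nM and compound 2 (`COc1ccc(C2=C(c3ccc(SC)cc3)CC3CCCN3C2=O)cc1OC(=O)CNC(=O)OC(C)(C)C`) gives 6000 nM, so the two stand within the scatter of each other. The change to compound 3 (`COc1ccc(C2=C(c3ccc(SC)cc3)CC3CCCN3C2=O)cc1Br`) is one bromine atom in place of a group of 12 heavy atoms (7 carbon, 1 nitrogen, 4 oxygen; no ring), on an aromatic carbon, ortho to a methoxy group. Among the compounds with values here, only one measured step bears on it: a 1.2-fold higher number from compound 1 to compound 2 (0.08 log units; within the scatter). Within the data shown here, no measured compound carries bromine, so that step offers limited guidance, and no shift beyond the scatter is expected. The estimated step is a 1.5-fold lower number from compound 2 to compound 3 (0.18 log units; within the scatter). For compound 3 the expected value is 4000 nM, with an estimated range from 1000 nM to 14000 nM.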

Compound 3, concentration for 50% growth inhibition: 800 nM
The estimate for compound 3 lay 5.0-fold (0.70 log units) above the measured number; the measured number lies below the stated range.
By their numbers in this assay, from the lowest: compound 3; then compounds 1 and 2 (each within the scatter of the next).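

Within the data shown here, at this aromatic carbon, ortho to a methoxy group, the earlier swap stayed within the scatter, whereas bromo in this assay gives a 7.5-fold lower number from compound 2 to compound 3 (0.88 log units; beyond the scatter) and also a 6.3-fold lower number from compound 1 to compound 3 (0.80 log units; beyond the scatter) as the first steps beyond it. Both steps point to stronger inhibition of growth, so the read-out does respond to what stands at this place. The compounds shown leave open whether chloro, a methyl group or an amine at this carbon would read like bromo. No evidence is available that explains the shift.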